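The source may hold more compounds than are shown below. What is called first, only, known or untested is meant among the compounds shown, and "the series" means these compounds.

Working notes on the series. Three compounds share the core of compound 1, `O=C(Cn1ccnc1)N1CCC(NS(=O)(=O)c2cc(S(=O)(=O)c3ccccc3)ccc2C(F)(F)F)CC1`, which in a functional assay on U2OS cells for antagonist activity at proto-oncogene Wnt-3 (Homo sapiens), read by a luciferase reporter, with a stated time of 18 h (a lower number here means that less compound is needed, a higher number that more compound is needed for the effect), gives 230 nM. Compound 2, `O=C1CC[C@@H](C(=O)N2CCC(NS(=O)(=O)c3cc(S(=O)(=O)c4ccccc4)ccc3C(F)(F)F)CC2)N1`, gives 240 nM; compound 2 and compound 1 sit together, the step of a 1.0-fold higher number from compound 1 to compound 2 (0.02 log units; within the scatter) lying within the scatter. Compound 3, `CCNC(=O)N1CCC[C@H]1C(=O)N1CCC(NS(=O)(=O)c2cc(S(=O)(=O)c3ccccc3)ccc2C(F)(F)F)CC1`, gives 90 nM and sits apart from both: the steps of a 2.6-fold lower number from compound 1 to compound 3 (0.41 log units; beyond the scatter) and a 2.7-fold lower number from compound 2 to compound 3 (0.43 log units; beyond the scatter) are both beyond the scatter, so compound 2 carries one of the two higher numbers seen so far, with compound 1 at its side.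

Compound 4, `CN(C)C(=O)N1CCC[C@H]1C(=O)N1CCC(NS(=O)(=O)c2cc(S(=O)(=O)c3ccccc3)ccc2C(F)(F)F)CC1`, is not yet measured. It differs from compound 2 in one place: 1-(dimethylcarbamoyl)pyrrolidin-2-yl in place of 5-oxopyrrolidin-2-yl on a carbonyl carbon. The closest measured step is a 2.7-fold lower number from compound 2 to compound 3 (0.43 log units; beyond the scatter), where an ethylcarbamoyl on the pyrrolidine nitrogen took the place of the ring carbonyl of the 5-oxopyrrolidin-2-yl; compound 4 carries a dimethylcarbamoyl at that same nitrogen instead. The step from compound 2 to compound 4 is therefore expected to resemble that one, a 2.2-fold lower number from compound 2 to compound 4 (0.34 log units; beyond the scatter), a modest move to a lower number. For compound 4 the estimate is 110 nM, with a range of 50 nM to 250 nM.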

Compound 4, half-maximal effective concentration: 160 nM
Compound 4: middle estimate off by 1.5-fold (0.16 log units), on the low side; the range from low to high includes it.
By their numbers in this assay, from the lowest: compounds 3, 4, 1 and 2 (each within the scatter of the next, the first and the last beyond it).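

In this assay, the 1-(dimethylcarbamoyl)pyrrolidin-2-yl group does not clearly separate from the earlier groups on this carbonyl carbon: a 1.5-fold lower number from compound 2 to compound 4 (0.18 log units; within the scatter) and a 1.4-fold lower number from compound 1 to compound 4 (0.16 log units; within the scatter) both lie within the scatter. The swap of ethylamino for dimethylamino is also unresolved, since a 1.8-fold higher number from compound 3 to compound 4 (0.25 log units; within the scatter) lies within the scatter as well. Compound 4 therefore overlaps all three earlier compounds, and the separation of compound 3 from compound 1 and compound 2 is not shown to extend to this closely related urea. No supporting data bear on this result.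

Still open, going by these compounds, is whether a methylamino group or a longer chain such as propylamino on this carbonyl carbon would resolve the effect of the amine substituent. A carboxylic acid on the pyrrolidine nitrogen would test a different kind of group there.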